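Formyl for hydrogen on the ring amine nitrogen

A few compounds are considered here, and "the series" means these few. Any claim that something is new, unique, unknown or untested is made for them only; others in the source may bear on it.

In a functional assay on the whole organism (strain Wistar) for inhibition, with Rattus norvegicus as the target, read by paw edema, with stated times of 30 min and 60 min, at a dose of 50 mg/kg by the oral route (a lower number here means less inhibition, a higher number more inhibition at the dose given (going by the name of the read-out)), compound 3 `Cc1ccc(C2=NNC(c3cn(-c4ccccc4)nc3-c3ccc(Cl)c(Cl)c3)C2)cc1` gives 56.5%, the second highest of three numbers; compound 1 `CC(=O)N1N=C(c2ccc(C)cc2)CC1c1cn(-c2ccccc2)nc1-c1ccc(Cl)c(Cl)c1` gives 59.5% and compound 2 `O=CN1N=C(c2ccc(Cl)cc2)CC1c1cn(-c2ccccc2)nc1-c1ccc(Cl)c(Cl)c1` gives 51.1%, both within the scatter of compound 3. Compound 4 `Cc1ccc(C2=NN(C=O)C(c3cn(-c4ccccc4)nc3-c3ccc(Cl)c(Cl)c3)C2)cc1` differs from compound 3 by formyl in place of hydrogen on an amine nitrogen in a ring. Among the compounds with values here, the one measured step that bears on this, a number 3 percentage points lower from compound 1 to compound 3 (within the scatter), was small; read in reverse, hydrogen to acetyl, it would add about as much. Compound 2 also carries a formyl on an amine nitrogen in a ring and sits within the scatter of compound 3. No change beyond the scatter is therefore expected for compound 4 in this assay, estimated at 57% with a range of 47% to 67%, a step of a number 0.5 percentage points higher from compound 3 to compound 4 (within the scatter).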

Compound 4, a percentage reported as inhibition, in the whole organism at one dose (the size of the read-out at that dose, not a potency): 53.4%
Compound 4: middle estimate off by 3.6 percentage points, on the high side; the measured number falls inside the stated range.
By their numbers in this assay, from the lowest: compounds 2, 4, 3 and 1 (each within the scatter of the next).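

On the ring amine nitrogen, formyl can now be read directly against hydrogen in this assay: a number 3.1 percentage points lower from compound 3 to compound 4 (within the scatter). Formyl against acetyl on that nitrogen gives a number 6.1 percentage points lower from compound 1 to compound 4 (within the scatter), and with formyl held there, methyl in place of chloro on an aromatic carbon gives a number 2.3 percentage points higher from compound 2 to compound 4 (within the scatter). No evidence bears on these steps.

From the compounds shown here alone, whether a benzoyl group or a longer acyl chain on that nitrogen would stay within the scatter remains open. So does the effect of a carboxylic acid on the phenyl ring of the 4-methylphenyl group.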